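Working notes: replacing the ethyl of compound 2

The source may report more compounds than this note shows. Statements on the series, on what has been measured and on what is new or still open speak of the compounds shown alone.

Compound 1 `COC(=O)C1=CO[C@@H](O[C@@H]2O[C@H](COC(c3ccccc3)(c3ccccc3)c3ccccc3)[C@@H](O)[C@H](O)[C@H]2O)[C@@H]2[C@@H](C)[C@@H](O)C[C@H]12` measured at 2.8 ug/mL
Compound 2 `CCC(=O)OC[C@H]1O[C@@H](O[C@@H]2OC=C(C(=O)OC)[C@H]3C[C@H](OC(C)=O)[C@H](C)[C@@H]23)[C@H](OC(C)=O)[C@@H](OC(C)=O)[C@@H]1OC(C)=O` measured at 4.26 ug/mL

In a functional assay on MCF7 cells (Homo sapiens) for cytotoxicity, read by colony formation (a lower number here means a stronger inhibitor, a higher number a weaker inhibitor), compound 2 stands at 4.26 ug/mL and compound 1 at 2.8 ug/mL and the two lie within the scatter of each other. Compound 3 `COC(=O)C1=CO[C@@H](O[C@@H]2O[C@H](COC(=O)c3cccc([N+](=O)[O-])c3)[C@@H](OC(C)=O)[C@H](OC(C)=O)[C@H]2OC(C)=O)[C@@H]2[C@@H](C)[C@@H](OC(C)=O)C[C@H]12` differs from compound 2 by 3-nitrophenyl in place of ethyl on a carbonyl carbon. For the measured compounds named here, no measured pair isolates this change. Nothing beyond the scatter is expected, and the estimated 1.2-fold lower number from compound 2 to compound 3 (0.09 log units; within the scatter) is small. The estimate for compound 3 is 3.5 ug/mL with an expected range from 1.5 ug/mL to 9 ug/mL in this assay as the read-out.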

Compound 3, half-maximal inhibitory concentration: 3.42 ug/mL
Compound 3: middle estimate off by 1.0-fold (0.01 log units), on the high side, within the range that was stated.
By their numbers in this assay, from the lowest: compounds 1, 3 and 2 (each within the scatter of the next).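

Placing 3-nitrophenyl in place of ethyl on a carbonyl carbon gives a 1.2-fold lower number from compound 2 to compound 3 (0.10 log units; within the scatter) in this assay. For the compounds shown here, this is the first step that isolates one place, and it shows that an aromatic ring can stand at this position with no change beyond the scatter. Nothing available bears on why this step is so small.

As far as these compounds go, it remains open whether a longer chain, or a phenyl ring carrying an amine or a carboxylic acid instead of the nitro group, would move the number beyond the scatter at this position.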